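Swapping Chloro for Hydroxy on a Shared Core

The source may hold more compounds than are shown below. What is called first, only, known or untested is meant among the compounds shown, and "the series" means these compounds.

Three compounds measured in a functional assay on RAW264.7 cells (Mus musculus) for inhibition; a lower number here means a stronger inhibitor, a higher number a weaker inhibitor:
compound 1 `O=C1/C(=C/c2ccccc2F)CCc2cc(O)ccc21`: 1740 nM
compound 2 `O=C1/C(=C/c2ccc(OC(F)(F)F)cc2)CCc2cc(O)ccc21`: 1350 nM
compound 3 `O=C1/C(=C/c2ccccc2Cl)CCc2cc(O)ccc21`: 1910 nM

Compound 3 gives the highest of the three numbers, but the spread is narrow: compound 1 sits a little lower, and compound 2, the furthest away, is still within the usual scatter of repeated measurements. All three share the same core and differ only in the substituent carried on the pendant aromatic ring.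

The next compound, compound 4 `O=C1/C(=C/c2ccccc2O)CCc2cc(O)ccc21`, is obtained from compound 3 by the change (hydroxy in place of chloro on an aromatic carbon). Among the measured compounds shown here, only one measured step bears on this position: a 1.1-fold higher number from compound 1 to compound 3 (0.04 log units; within the scatter), a step within the scatter. For the measured compounds named here, that step exchanged one halogen for another; no measured pair shows what a hydroxy group does at this position, so the expectation for compound 4 rests on the narrow range of the three values and on the flat halogen step alone.

On that basis the expected step from compound 3 to compound 4 in this assay is small, a 1.1-fold lower number from compound 3 to compound 4 (0.03 log units; within the scatter), with no clear direction beyond the scatter. Compound 4 is therefore estimated at 1800 nM, in a range from 800 nM to 4000 nM.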

Compound 4, half-maximal inhibitory concentration: 550 nM
Compound 4: the middle estimate sits 3.3-fold (0.51 log units) above what was measured, and the stated range ends above it.
By their numbers in this assay, from the lowest: compound 4; then compounds 2, 1 and 3 (each within the scatter of the next).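

In this assay the position on the pendant ring, which looked indifferent when one halogen replaced another, turns out to respond to the group it carries: hydroxy in place of chloro gives a 3.5-fold lower number from compound 3 to compound 4 (0.54 log units; beyond the scatter) and hydroxy in place of fluoro gives a 3.2-fold lower number from compound 1 to compound 4 (0.50 log units; beyond the scatter). Both steps are modest in size but lie beyond the scatter, so at this place, ortho to a large group, the two halogens stay within the scatter of each other while hydroxy stands apart from both. The change also swaps a chloro, counted with no hydrogen-bond donor or acceptor, for a hydroxy, counted as both, but no measurement here explains why the number falls.

The compounds shown leave open whether this drop is particular to hydroxy or would also appear with an amine, a methoxy group or a carboxylic acid at the same place. Among the compounds shown here, with only one hydroxy compound on the pendant ring, they also cannot show whether the step would hold if the hydroxy were moved elsewhere on that ring.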